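Swapping cyclopropyl for an aryl amide: notes on compound 4

The source may report more compounds than this note shows. Statements on the series, on what has been measured and on what is new or still open speak of the compounds shown alone.

Three measured compounds share the core of compound 1 (`COc1cc(-c2nnc(S)n2-c2ccc(N(C)C)cc2)cc(OC)c1OC`). In a functional assay on HCT-116 cells (Homo sapiens) for inhibition, read by MTT assay, with a stated time of 48 h (on this read-out lower numbers stand for stronger inhibition and higher numbers for weaker inhibition), compound 1 gives > 60000 nM, which is a limit and not a number. In this assay compound 2 (`COc1cc(-c2nnc(SCc3ccc(C)cc3)n2-c2ccc(N(C)C)cc2)cc(OC)c1OC`) gives > 60000 nM, also a limit. In this assay compound 3 (`COc1cc(-c2nnc(SCC(=O)C3CC3)n2-c2ccc(N(C)C)cc2)cc(OC)c1OC`) gives > 60000 nM, again a limit, so it has no numerical place in the series. The record so far is the limit of > 60000 nM in this assay, at which 3 of the 3 values shown sit.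

Compound 4 (`COc1cc(-c2nnc(SCC(=O)Nc3ccc(Cl)cc3)n2-c2ccc(N(C)C)cc2)cc(OC)c1OC`) differs from compound 3 as follows: (4-chlorophenyl)amino in place of cyclopropyl on a carbonyl carbon. The (cyclopropylcarbonyl)methyl on sulfur thus becomes ((4-chlorophenyl)carbamoyl)methyl.

The measured steps that bear on this change all concern the group on sulfur: a step that the two limits leave unreadable from compound 1 to compound 2, a step that the two limits leave unreadable from compound 1 to compound 3 and a step that the two limits leave unreadable from compound 2 to compound 3. Among the measured compounds shown here, none of them supplies a size or a direction, and the (4-chlorophenyl)amino group has no measured precedent here. The expectation therefore rests on (the limit of > 60000 nM in this assay, at which 3 of the 3 values shown sit), with a reported limit about as likely as a number. Any measurable change is expected to be towards stronger inhibition, since a limit is the only alternative. The expected step is an at least 1.5-fold lower number from compound 3 to compound 4 (0.17 log units; that floor lies within the scatter). For compound 4 the estimated value is 40000 nM, with an expected range of 6000 nM to 80000 nM.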

Compound 4, half-maximal inhibitory concentration: 39300 nM
For compound 4 the middle estimate is 1.0-fold (0.01 log units) above the measured one; the measured number falls inside the stated range.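

In this assay, the steps among compound 1, compound 2 and compound 3 cannot be read, while the group on sulfur in compound 4 yields the only number shown, so this position can now carry a readable value. Taking (4-chlorophenyl)amino in place of cyclopropyl on a carbonyl carbon gives an at least 1.5-fold lower number from compound 3 to compound 4 (0.18 log units; that floor lies within the scatter), (4-chlorophenyl)carbamoyl in place of 4-methylphenyl gives an at least 1.5-fold lower number from compound 2 to compound 4 (0.18 log units; that floor lies within the scatter), and the whole ((4-chlorophenyl)carbamoyl)methyl group in place of hydrogen on sulfur gives an at least 1.5-fold lower number from compound 1 to compound 4 (0.18 log units; that floor lies within the scatter). Each of these is only a floor on the step, so its full size stays unknown, and the series remains dominated by limits: the limit of > 60000 nM in this assay, at which 3 of the 4 values shown sit.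

The compounds shown do not separate the parts of the new group, so the amide hydrogen, the aromatic ring and the chlorine cannot be weighed against one another. Unsubstituted phenylamino, 4-methoxyphenylamino, a simple methylamino or a carboxylic acid on the same carbonyl carbon would each test a different part of that change.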